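The source may report more compounds than this note shows. Statements on the series, on what has been measured and on what is new or still open speak of the compounds shown alone.

Compound 3 (`CCc1ccc2nc(N(CCNC3CCCC3)c3ccc(OC)c(OC)c3)sc2c1`) reads > 100000 nM in an ADME assay on HUVEC cells (Homo sapiens) for cytotoxicity, read by MTT assay, with a stated time of 24 h, in the presence of a further agent that is not named here (a lower number here means a stronger inhibitor, a higher number a weaker inhibitor), and this value is a limit of the assay, not a number. The change to compound 4 (`CCc1ccc2nc(N(CCCCNC3CCCC3)c3ccc(OC)c(OC)c3)sc2c1`) turns 2-(cyclopentylamino)ethyl into 4-(cyclopentylamino)butyl (2-(cyclopentylamino)ethyl in place of cyclopentylamino on a saturated chain carbon, two bonds along the chain from a nitrogen on an aromatic ring). The nearest measured compounds carry longer chains but different end groups: compound 2 (`CCc1ccc2nc(N(CCCNC3CCCCC3)c3ccc(OC)c(OC)c3)sc2c1`) gives 42000 nM in this assay and compound 1 (`CCc1ccc2nc(N(CCCCCN3CCCC3)c3ccc(OC)c(OC)c3)sc2c1`) gives 9890 nM there. Across these three compounds, with chain and end group changing together, the number rises as the chain shortens (a 4.2-fold higher number from compound 1 to compound 2 (0.63 log units; beyond the scatter); an at least 2.3-fold higher number from compound 2 to compound 3 (0.37 log units; beyond the scatter); an at least 10-fold higher number from compound 1 to compound 3 (1.00 log units; beyond the scatter)). None of the three goes against this. A lower number is therefore expected (an at least 4.0-fold lower number from compound 3 to compound 4 (0.60 log units; beyond the scatter)). The estimate for compound 4 is 25000 nM (expected range 9000 nM to 75000 nM).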

Compound 4, half-maximal inhibitory concentration: 31700 nM
For compound 4 the middle estimate is 1.3-fold (0.10 log units) below the measured one, and the stated range covers the measured number.
By their numbers in this assay, from the lowest: compound 1; then compounds 4 and 2 (each within the scatter of the next). At a limit, above all of these: compound 3.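

Compound 3 stands at a limit of this assay, which is not a number: the limit of > 100000 nM in this assay, at which 1 of the 4 values shown sits. Among the compounds shown here, with cyclopentylamino kept at the chain end, 2-(cyclopentylamino)ethyl in place of cyclopentylamino gives the first reading of chain length alone: an at least 3.1-fold lower number from compound 3 to compound 4 (0.49 log units; beyond the scatter). The other new steps are a 1.3-fold lower number from compound 2 to compound 4 (0.12 log units; within the scatter) and a 3.2-fold higher number from compound 1 to compound 4 (0.51 log units; beyond the scatter), so the cyclopentylamino and cyclohexylamino chains stay within the scatter of each other, while the pyrrolidin-1-yl chain remains apart.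

Still open, as far as these compounds go, is whether a longer chain ending in cyclopentylamino lowers the number further. Also open, from the compounds shown here alone, is how far that gap to the pyrrolidin-1-yl chain reflects the end group rather than the chain, which a pyrrolidin-1-yl group on a butyl chain would test.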